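Replacing Chloro with Methoxy on a Weakly Cytotoxic Amide

The compounds below may be only part of what the source reports. "The series", "measured", "known", "first", "only" and "open" are said of these compounds alone.

In an ADME assay on Raji cells (Homo sapiens) for cytotoxicity, with a stated time of 72 h (on this read-out lower numbers stand for an effect already at smaller amounts and higher numbers for an effect only at larger amounts of compound), compound 1 `O=C(Nc1cc(-c2nc3ccccc3s2)ccc1Cl)c1cc([N+](=O)[O-])ccc1Cl` gives only a limit, > 25000 nM. Compound 3 `O=C(Nc1cc(-c2nc3ccccc3o2)ccc1F)c1cc([N+](=O)[O-])ccc1Cl` likewise reaches only a limit, > 25000 nM. Compound 2 `O=C(Nc1nc(-c2ccc(Cl)cc2)cs1)c1cc([N+](=O)[O-])ccc1Cl` is the one of the three that returns a number, 12000 nM. Compound 1 therefore sits at the limit of > 25000 nM in this assay, at which 2 of the 3 values shown sit, so where it stands among these values cannot be placed more exactly than that. Compound 4 `COc1ccc(-c2nc3ccccc3s2)cc1NC(=O)c1cc([N+](=O)[O-])ccc1Cl` differs from compound 1 by methoxy in place of chloro on an aromatic carbon. Going by the values given here, no measured pair shows this change, so the size of its step in this assay is open; one expects no more than a modest shift, within the scatter or slightly toward an effect at smaller amounts. Compound 4 is estimated at 20000 nM, between 7000 nM and 25000 nM. The expected step is an at least 1.2-fold lower number from compound 1 to compound 4 (0.09 log units; that floor lies within the scatter).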

Compound 4, half-maximal effective concentration: > 25000 nM
Compound 4 gave a limit, no number (the forecaster's own chance of this, stated with the estimate: 55%); middle value at least 1.2-fold (0.09 log units) from the limit.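

Compound 1 and compound 4 both end at a limit, so no step between them can be read: the limit of > 25000 nM in this assay, at which 3 of the 4 values shown sit.

The compounds shown leave open how far methoxy in place of chloro on an aromatic carbon moves the value in this assay.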